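Ester Capping and a Warhead Swap in One Cell Assay

This account rests on a few compounds, and the source may have more. Where it says the series, first, only, none or still open, it means among the compounds named here.

Compound 1 `C=CC(=O)Nc1ccc(Cn2nc(-c3ccc(Oc4ccccc4)cc3)cc2C(=O)O)cc1` gives > 60000 nM, a limit of the assay. Compound 2 `C=CC(=O)Nc1ccc(Cn2nc(-c3ccc(Oc4ccccc4)cc3)cc2C(=O)OCC)cc1` gives 2800 nM. Compound 3 `O=C(CCl)Nc1ccc(Cn2nc(-c3ccc(Oc4ccccc4)cc3)cc2C(=O)O)cc1` gives 4000 nM.

All three were measured in a functional assay on Rec1 cells (Homo sapiens) for inhibition, read by luminescence and CellTiter-Glo, with a stated time of 72 h; on this read-out lower numbers stand for stronger inhibition and higher numbers for weaker inhibition. For compound 1 only the limit is known, (the limit of > 60000 nM in this assay, at which 1 of the 3 values shown sits). Two single changes leave that limit behind. The first, (ethyl in place of hydrogen on an oxygen next to a carbonyl group), gives an at least 21-fold lower number from compound 1 to compound 2 (1.33 log units; beyond the scatter). The second, (chloromethyl in place of vinyl on a carbonyl carbon), gives an at least 15-fold lower number from compound 1 to compound 3 (1.17 log units; beyond the scatter). Compound 3 and compound 2 lie within the usual scatter of each other, so no order between them is claimed.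

Compound 4 `CCOC(=O)c1cc(-c2ccc(Oc3ccccc3)cc2)nn1Cc1ccc(NC(=O)CCl)cc1` has not been measured. It differs from compound 3 by ethyl in place of hydrogen on an oxygen next to a carbonyl group, the same change as from compound 1 to compound 2, at the same place. The cores of compound 3 and compound 1 differ by chloromethyl in place of vinyl on a carbonyl carbon. The earlier step starts from compound 1, which sits at a limit of the assay. For compound 4 a clear but smaller step is expected, a 5.0-fold lower number from compound 3 to compound 4 (0.70 log units; beyond the scatter), resting on an at least 21-fold lower number from compound 1 to compound 2 (1.33 log units; beyond the scatter) and on the value of compound 3, 4000 nM. Compound 4 is therefore estimated at 800 nM, between 200 nM and 3000 nM.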

Compound 4, half-maximal inhibitory concentration: 400 nM
For compound 4 the middle estimate is 2.0-fold (0.30 log units) above the measured one; the measured number falls inside the stated range.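

In this assay both changes keep their direction on the second core: ethyl in place of hydrogen on an oxygen next to a carbonyl group lowers the number on the chloromethyl core (a 10-fold lower number from compound 3 to compound 4 (1.00 log units; beyond the scatter)), and chloromethyl in place of vinyl on a carbonyl carbon lowers it on the core carrying ethoxycarbonyl (a 7.0-fold lower number from compound 2 to compound 4 (0.85 log units; beyond the scatter)). This shows that the direction of the ethyl change carries over, but not that its size does: the same change on two cores in this assay, an at least 21-fold lower number (1.33 log units; beyond the scatter) from compound 1 to compound 2 and a 10-fold lower number (1.00 log units; beyond the scatter) from compound 3 to compound 4; the limit leaves it open whether they differ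

The swap on the carbonyl carbon is no better fixed in size, since its earlier step also starts from compound 1, which is known only as a limit of the assay: the same change on two cores in this assay, an at least 15-fold lower number (1.17 log units; beyond the scatter) from compound 1 to compound 3 and a 7.0-fold lower number (0.85 log units; beyond the scatter) from compound 2 to compound 4; the limit leaves it open whether they differ

The compounds shown leave open whether methyl or a longer chain on that oxygen would give a step like that of ethyl. They also leave open whether bromomethyl or a chain ending in an amine on the carbonyl carbon would follow chloromethyl.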